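A few compounds are considered here, and "the series" means these few. Any claim that something is new, unique, unknown or untested is made for them only; others in the source may bear on it.

Measured so far in a functional assay on SW480 cells (Homo sapiens) for inhibition, read by luminescence and resazurin assay, with a stated time of 3 days; on this read-out higher numbers stand for weaker inhibition and lower numbers for stronger inhibition:
compound 1 `CN1CCN(c2nc(NCc3ccc(NC(=O)c4ccc(F)cc4)cc3)c3ccccc3n2)CC1` — 2500 nM
compound 2 `CN(C)CCCNc1nc(NCc2ccc(NC(=O)c3ccc(F)cc3)cc2)c2ccccc2n1` — 14000 nM

Within the data shown here, compound 2 holds the higher of the two numbers; compound 1 sits below it, and a 5.6-fold higher number from compound 1 to compound 2 (0.75 log units; beyond the scatter) is the only measured step in the set. That step concerns the amine-bearing group on the shared core, not the benzamide end. Compound 3 `CN(C)CCCNc1nc(NCc2ccc(NC(=O)c3ccc(CN4CCN(C)CC4)cc3)cc2)c2ccccc2n1` differs from compound 2 at the benzamide end: (4-methylpiperazin-1-yl)methyl in place of fluoro on an aromatic carbon. Among the measured compounds shown here, no measured step touches this position, so the one step on record gives no direct guidance; it shows only that the read-out in this assay can move beyond the scatter when a group is exchanged elsewhere. With no anchor for the present change, compound 3 is expected to land near compound 2 in this assay, with a wide range on both sides, the expected step being a 1.4-fold lower number from compound 2 to compound 3 (0.15 log units; within the scatter). Compound 3 is estimated at 10000 nM, between 2500 nM and 40000 nM.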

Compound 3, half-maximal inhibitory concentration: > 20000 nM
Compound 3: a limit, no number (the forecaster's own chance of this, stated with the estimate: 15%); middle value at least 2.0-fold (0.30 log units) from the limit.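

In this assay, compound 3 gives > 20000 nM, which is a limit of the assay and not a number. Among these compounds, this is the first reading at the benzamide end: (4-methylpiperazin-1-yl)methyl in place of fluoro, on an aromatic carbon para to a large group, gives an at least 1.4-fold higher number from compound 2 to compound 3 (0.15 log units; that floor lies within the scatter), so this exchange brings no lower number, though its printed floor lies within the scatter. The reading therefore bounds the change from one side only: the limit of > 20000 nM in this assay, at which 1 of the 3 values shown sits.

From the compounds shown here alone, the true size of the step stays open, including whether it lies beyond the scatter. Also open, going by these compounds, is how a carboxylic acid or a morpholine ring would read at this place, and whether (4-methylpiperazin-1-yl)methyl would read the same with the 4-methylpiperazin-1-yl group of compound 1 on the shared core.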